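Cytotoxicity notes on an amide series, compound 3 to compound 4

The source may report more compounds than this note shows. Statements on the series, on what has been measured and on what is new or still open speak of the compounds shown alone.

Measured so far:
compound 1 `CN(C)c1c(C(=O)NCc2ccc(F)cc2F)c(=O)n(O)c2ncccc12`, in an ADME assay on HOS cells (Homo sapiens) for cytotoxicity, read by a luciferase reporter and ATP content (a lower number here means that less compound is tolerated, a higher number that more compound is tolerated), compound 1 gives 13000 nM
compound 2 `O=C(NCc1ccc(F)cc1F)c1c(NC2CCCCCC2)c2cccnc2n(O)c1=O`, in this assay compound 2 gives 68000 nM
compound 3 `O=C(NCc1ccc(F)cc1F)c1c(NCCO)c2cccnc2n(O)c1=O`, in this assay compound 3 gives 24000 nM

All three share one core and differ only in the amino substituent on the aromatic carbon. Compound 3 holds the second highest of the three numbers; its nearest neighbour is compound 1, and that gap, a 1.8-fold higher number from compound 1 to compound 3 (0.27 log units; within the scatter), lies within the scatter; the gap to compound 2, a 2.8-fold lower number from compound 2 to compound 3 (0.45 log units; beyond the scatter), lies beyond it.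

Compound 4 `COC(=O)CNc1c(C(=O)NCc2ccc(F)cc2F)c(=O)n(O)c2ncccc12` is the next member. The change from compound 3 is methoxycarbonyl in place of hydroxymethyl on a saturated chain carbon bound to a nitrogen on an aromatic ring.

Every measured step bears on this position, since each also exchanges the group on that aromatic carbon: a 5.2-fold higher number from compound 1 to compound 2 (0.72 log units; beyond the scatter), a 1.8-fold higher number from compound 1 to compound 3 (0.27 log units; within the scatter) and a 2.8-fold lower number from compound 2 to compound 3 (0.45 log units; beyond the scatter). For the measured compounds named here, none of these is large, and the one closest in kind, a change on the chain of the (2-hydroxyethyl)amino group, has no direct precedent. The expectation for compound 4 is therefore a step of a 1.1-fold lower number from compound 3 to compound 4 (0.04 log units; within the scatter), which is to say none beyond the scatter, with the wider range reflecting the modest movements seen across the three. Compound 4 is thus estimated at 22000 nM in this assay, expected to fall between 9000 nM and 55000 nM.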

Compound 4, half-maximal cytotoxic concentration: > 250000 nM
Compound 4 ended at the assay's limit (the forecaster's own chance of this, stated with the estimate: 5%); middle value at least 11-fold (1.05 log units) from the limit.
By their numbers in this assay, from the lowest: compounds 1 and 3 (each within the scatter of the next); then compound 2. At a limit, above all of these: compound 4.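

In this assay compound 4 reads as a limit of the assay and not as a number: the limit of > 250000 nM in this assay, at which 1 of the 4 values shown sits.

For the compounds shown here, this position proves far more responsive than compounds 1 to 3 suggested: methoxycarbonyl in place of hydroxymethyl on a saturated chain carbon bound to a nitrogen on an aromatic ring gives an at least 10-fold higher number from compound 3 to compound 4 (1.01 log units; beyond the scatter), a large step from one small exchange, where the earlier steps were modest or within the scatter. The new amino group also clears the other two members of the series, with an at least 3.6-fold higher number from compound 2 to compound 4 (0.56 log units; beyond the scatter) and an at least 19-fold higher number from compound 1 to compound 4 (1.28 log units; beyond the scatter), so that a change on the chain alone outruns the exchange of the whole amino group seen between compound 1 and compound 2.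

Going by these compounds, how far compound 4 lies past the limit remains unknown, so all three steps carry only a lower bound. On these data alone, whether the shift belongs to methoxycarbonyl as such remains open, and a carboxylic acid, a primary amide or a longer chain ending in methoxycarbonyl at this place would help to separate the contribution of the group from that of the chain.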